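The source may hold more compounds than are shown below. What is called first, only, known or untested is meant among the compounds shown, and "the series" means these compounds.

In a functional assay on DU-145 cells (Homo sapiens) for cytotoxicity, read by CCK-8 assay and cell counting, with a stated time of 2 days (a lower number here means a stronger inhibitor, a higher number a weaker inhibitor), compound 1 `Oc1ccc(-c2cc(-c3ccc(Cl)cc3)nc(-c3cccnc3)c2)cc1` gives 22800 nM. Compound 2 `Oc1ccc(-c2cc(-c3ccc(Cl)cc3)nc(-c3cccs3)c2)cc1` differs from compound 1 in one place, (thiophen-2-yl in place of pyridin-3-yl on an aromatic carbon), and in this assay compound 2 gives 7660 nM; the step of a 3.0-fold lower number from compound 1 to compound 2 (0.47 log units; beyond the scatter) is the one measured reference for this change.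

Compound 3 `Oc1cccc(-c2cc(-c3cccnc3)nc(-c3ccccc3Cl)c2)c1` has the same atoms as compound 1 joined differently; the difference between the two cores is not broken down here. In this assay compound 3 gives "not determined" (no result reported), so the series offers no anchor for its core.

Compound 4 `Oc1cccc(-c2cc(-c3cccs3)nc(-c3ccccc3Cl)c2)c1` carries the same change relative to compound 3, (thiophen-2-yl in place of pyridin-3-yl on an aromatic carbon). The place differs from the earlier one: there the site sat meta to a 4-chlorophenyl group and meta to a 4-hydroxyphenyl group, here meta to a 2-chlorophenyl group and meta to a 3-hydroxyphenyl group. It is therefore the same kind of change, not the same one, and with compound 3 unmeasured there is nothing to set a step against.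

The expectation for compound 4 rests only on compound 1 at 22800 nM and compound 2 at 7660 nM, taken as the rough range for cores of this family with the thiophen-2-yl group present. Compound 4 is expected at about 10000 nM in this assay, with a wide band from 2500 nM to 40000 nM. The band is wide: the core of compound 3 has no measured number of its own, its entry in this assay standing as "not determined" (no result reported).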

Compound 4, half-maximal inhibitory concentration: 1700 nM
Compound 4: the middle estimate sits 5.9-fold (0.77 log units) above what was measured; the whole stated range lies above it.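

No step can be read from compound 3 to compound 4: in this assay compound 3 stands as "not determined" (no result reported) and so gives compound 4 no partner. Nothing shown bears on the result. Left open is whether thiophen-2-yl in place of pyridin-3-yl acts on the core of compound 3 as it does between compound 1 and compound 2, and how the two cores compare.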